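Swapping a Branched Alkyl Chain for a Methoxybenzyl Group

The compounds below may be only part of what the source reports. "The series", "measured", "known", "first", "only" and "open" are said of these compounds alone.

The measured compounds are:
compound 1 `O=C(Nc1ncc(C(=O)O)c2nc(-c3ccco3)nn12)NC1CCCCC1` with 59400 nM;
compound 2 `CCNc1ncc(C(=O)O)c2nc(-c3ccco3)nn12` with 480 nM;
compound 3 `CCCCC(CC)CNc1ncc(C(=O)O)c2nc(-c3ccco3)nn12` with 16400 nM.

In an assay on CHO cells for displacement of a labelled ligand from adenosine receptor A3 (Homo sapiens) (a lower number here means a stronger inhibitor, a higher number a weaker inhibitor), compound 3 stands second highest of the three numbers. It sits closer to compound 1, as the step of a 3.6-fold lower number from compound 1 to compound 3 (0.56 log units; beyond the scatter) shows, and far from compound 2, as the step of a 34-fold higher number from compound 2 to compound 3 (1.53 log units; beyond the scatter) shows.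

Compound 4 `COc1ccc(CNc2ncc(C(=O)O)c3nc(-c4ccco4)nn23)cc1` differs from compound 3 by 4-methoxyphenyl in place of 1-ethylpentyl on a saturated chain carbon bound to a nitrogen on an aromatic ring. The step that bears most on this change is a 34-fold higher number from compound 2 to compound 3 (1.53 log units; beyond the scatter): extending the substituent on the ring nitrogen from ethyl to 2-ethylhexyl raised the number greatly, so the branched chain itself appears to be costly, and taking it away points toward a lower number. The step of a 3.6-fold lower number from compound 1 to compound 3 (0.56 log units; beyond the scatter) shows that a very different group in the same place can also move the number a good deal. Going by the values given here, no measured compound carries an aromatic ring in this position, so the size of the step in this assay is uncertain; a lower number, beyond the scatter, is expected, with compound 4 expected to fall nearer compound 2 than compound 1 but not to reach compound 2.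

For compound 4 the expected step is a 6.6-fold lower number from compound 3 to compound 4 (0.82 log units; beyond the scatter). Compound 4 is therefore estimated at 2500 nM, within the range 400 nM to 15000 nM.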

Compound 4, inhibition constant: 5520 nM
Beside the measured number, compound 4's estimate is 2.2-fold (0.34 log units) below it, within the range that was stated.
By their numbers in this assay, from the lowest: compound 2; then compound 4; then compound 3; then compound 1.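

In this assay, going by these compounds alone, the exchange of 2-ethylhexyl for 4-methoxybenzyl on a nitrogen on an aromatic ring gives a 3.0-fold lower number from compound 3 to compound 4 (0.47 log units; beyond the scatter) and shows that a group carrying an aromatic ring, absent from the earlier compounds, can stand in this place with a lower number than the branched chain. The same group gives an 11-fold lower number from compound 1 to compound 4 (1.03 log units; beyond the scatter) and also a 12-fold higher number from compound 2 to compound 4 (1.06 log units; beyond the scatter) so that it falls well clear of the cyclohexylcarbamoyl compound but does not come close to the ethyl compound, which keeps the lowest number of the four. The shown compounds offer no explanation for the order of these groups, and no measurement bears on why the numbers move as they do.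

The compounds shown leave open whether the methoxy group adds anything to the effect of the benzyl group, which a plain benzyl group or a 4-chlorobenzyl group in the same place would test. They also leave open how the number changes between ethyl and the larger groups, for which a straight propyl or butyl chain, or a phenyl ring set directly on the nitrogen, would fill in the picture.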